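Permeability notes: amide aryl swap on the shared core

A few compounds are considered here, and "the series" means these few. Any claim that something is new, unique, unknown or untested is made for them only; others in the source may bear on it.

Measured so far:
- compound 1, `Cc1cc(-c2ccnc3[nH]c(-c4cnn(C)c4)nc23)ccc1CNC(=O)c1ccc(C(C)(C)C)cc1` — 0.2 10^-6 cm/s
- compound 2, `Cn1cc(-c2nc3c(-c4ccc(CNC(=O)c5ccc(C(C)(C)C)cc5)c(F)c4)ccnc3[nH]2)cn1` — 0.4 10^-6 cm/s

In an ADME assay on Caco-2 cells (Homo sapiens) for permeability, in the apical to basolateral direction (a higher number here means that the compound crosses the layer faster, a lower number that the compound crosses the layer more slowly), compound 1 gives 0.2 10^-6 cm/s and compound 2 gives 0.4 10^-6 cm/s. Going by the values given here, the one step between them, a 2.0-fold higher number from compound 1 to compound 2 (0.30 log units; within the scatter), changes only the substituent on the aromatic carbon and leaves the amide side untouched. Compound 2 holds the higher of the two numbers, but its gap to compound 1 lies within the scatter, so neither compound can be set above the other.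

The unmeasured compound 3, `Cn1cc(-c2nc3c(-c4ccc(CNC(=O)c5nc(C(C)(C)C)no5)c(F)c4)ccnc3[nH]2)cn1`, differs from compound 2 at the carbonyl carbon: a group of 9 heavy atoms (6 carbon, 2 nitrogen, 1 oxygen; one five-membered aromatic ring with 3 hetero atoms) in place of a group of 10 heavy atoms (10 carbon; one six-membered aromatic ring of carbon only), on a carbonyl carbon. Among the compounds with values here, no measured step touches this part of the molecule; the only step known, the fluoro-for-methyl exchange, says nothing about what happens when the 4-(tert-butyl)phenyl group is replaced. Within the data shown here, with both measured compounds sitting close together and no relevant precedent, no step beyond the scatter is expected in either direction.

For compound 3 the number is therefore estimated at 0.3 10^-6 cm/s, with a range of 0.1 10^-6 cm/s to 0.9 10^-6 cm/s, which corresponds to an expected step of a 1.3-fold lower number from compound 2 to compound 3 (0.12 log units; within the scatter).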

Compound 3, apparent permeability: 11 10^-6 cm/s
Beside the measured number, compound 3's estimate is 37-fold (1.56 log units) below it; measured number outside the range, above it.
By their numbers in this assay, from the lowest: compounds 1 and 2 (each within the scatter of the next); then compound 3.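

In this assay, going by these compounds alone, the exchange on the carbonyl carbon gives a 28-fold higher number from compound 2 to compound 3 (1.44 log units; beyond the scatter) and is the first step to lie beyond the scatter, whereas the fluoro-for-methyl exchange on the aromatic carbon stayed within it. The heavy-atom count barely differs, with 9 heavy atoms in place of 10 heavy atoms, but a six-membered aromatic ring of carbon only gives way to a five-membered aromatic ring with 3 hetero atoms, and the hydrogen-bond acceptors in the group go from 0 to 3. This single pair therefore marks the group on the carbonyl carbon as a place where the read-out can shift strongly, and no measurement at hand accounts for the step.

The compounds shown cannot separate the ring type from the hetero atoms, or show whether the step depends on any one of them; a pyridine ring or a different five-membered aromatic ring in this place would address that. They also leave open whether the step carries over to the methyl compound, compound 1, or persists if a cyclopropyl group replaces the tert-butyl group.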